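The source may report more compounds than this note shows. Statements on the series, on what has been measured and on what is new or still open speak of the compounds shown alone.

Measured so far: compound 1, `COC(=O)/C=C(C)/C=C/C(F)=C(C)\C=C\c1c(C)cc(OC)c(C)c1C`, gives 17%; compound 2, `CCNC(=O)/C=C(C)/C=C/C(F)=C(C)/C=C/c1c(C)cc(OC)c(C)c1C`, gives 53%; compound 3, `COC(=O)/C=C(C)/C=C/C=C(\C=C\c1c(C)cc(OC)c(C)c1C)C(F)(F)F`, gives 25%. All three were tested in a functional assay on the whole organism (strain Hart Swiss) with Mus musculus as the target, with stated times of 5 days and 2 weeks, at a dose of 80 mg/kg by the intraperitoneal route; a lower number here means a weaker effect, a higher number a stronger effect of the compound at the dose given.

Compound 2 stands highest of the three numbers. Its nearest neighbour is compound 3, whose value lies lower by a gap beyond the scatter; compound 1 lies further below, also beyond the scatter.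

Compound 4, `CCOC(=O)/C(F)=C(C)/C=C/C(F)=C(C)/C=C/c1c(C)cc(OC)c(C)c1C`, has not yet been tested. It differs from compound 2 in one place: a group of 9 heavy atoms (6 carbon, 2 oxygen, 1 fluorine; no ring) in place of a group of 8 heavy atoms (6 carbon, 1 nitrogen, 1 oxygen; no ring), on a double-bonded chain carbon bound to a double-bonded chain carbon. The group that leaves carries one hydrogen-bond donor and contains a nitrogen; the group that enters carries no donor, holds two oxygens and one fluorine, and has two hydrogen-bond acceptors.

Going by the values given here, no measured pair shows this exact step, so its size in this assay can only be guessed. Among the measured compounds, the two without a nitrogen in this group sit well below compound 2: compound 1 gives 17% and compound 3 gives 25%. On that basis a downward step is expected, a number 23 percentage points lower from compound 2 to compound 4 (beyond the scatter). Compound 4 is therefore estimated at 30%, within a range from 12% to 55%.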

Compound 4, a percentage reported as activity, at one dose (the size of the read-out at that dose, not a potency): 35%
Compound 4: the middle estimate sits 5 percentage points below what was measured, and the stated range covers the measured number.
By their numbers in this assay, from the lowest: compounds 1, 3 and 4 (each within the scatter of the next, the first and the last beyond it); then compound 2.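

Going by these compounds alone, compounds 2 and 4 give the first direct reading at this place, a double-bonded chain carbon bound to a double-bonded chain carbon. In this assay, putting the group with two oxygens and one fluorine in place of the group with the nitrogen gives a number 18 percentage points lower from compound 2 to compound 4 (beyond the scatter), so the group held here does affect the read-out at this dose. The effect shrinks without vanishing, as compound 4 still gives 35%, and no data at hand explain the change.

Within the data shown here, the single step changes several things at once, so it remains open whether the fluorine or the loss of the nitrogen with its hydrogen accounts for it; an ethyl ester without the fluorine would help separate the two. On these data alone, how a carboxylic acid or an amide with a longer chain would read at this place also remains open.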